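The source may hold more compounds than are shown below. What is called first, only, known or untested is meant among the compounds shown, and "the series" means these compounds.

Three compounds share one core and differ mainly in the group hung on one of its ester oxygens. Compound 1 `C/C=C1/[C@H](O[C@@H]2O[C@H](CO)[C@@H](O)[C@H](O)[C@H]2O)OC=C(C(=O)O)[C@H]1CC(=O)OC` carries no extended side group there. In a functional assay on SK-BR-3 cells (Homo sapiens) for antiproliferative activity, read by MTT assay, with a stated time of 72 h (a higher number here means a weaker inhibitor, a lower number a stronger inhibitor), compound 1 gives only a limit, > 20000 nM. Compound 2 `C/C=C1/[C@H](O[C@@H]2O[C@H](CO)[C@@H](O)[C@H](O)[C@H]2O)OC=C(C(=O)OC)[C@H]1CC(=O)OCCCCCCCCCCCCCCC` carries a dodecyl chain; in this assay compound 2 gives 1600 nM. Compound 3 `C/C=C1/[C@H](O[C@@H]2O[C@H](CO)[C@@H](O)[C@H](O)[C@H]2O)OC=C(C(=O)OC)[C@H]1CC(=O)OCCCc1ccc(OC)c(OC)c1` carries instead a 3,4-dimethoxyphenyl on a saturated chain carbon, three bonds along the chain from an oxygen next to a carbonyl group. In this assay compound 3 gives only a limit, > 20000 nM. Compound 3 thus stands at the weak edge of the numbers shown, and the single step of an at least 12-fold higher number from compound 2 to compound 3 (1.09 log units; beyond the scatter) is what separates it from the only compound with a real number.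

Compound 4 `C/C=C1/[C@H](O[C@@H]2O[C@H](CO)[C@@H](O)[C@H](O)[C@H]2O)OC=C(C(=O)OC)[C@H]1CC(=O)OCCc1ccc(OC)cc1` is not yet measured. It differs from compound 3 as follows: 4-methoxyphenyl in place of 3,4-dimethoxybenzyl on a saturated chain carbon, two bonds along the chain from an oxygen next to a carbonyl group. Going by the values given here, only the step from compound 2 to compound 3 bears on this, and it was large, but it set an aromatic group against a chain rather than one aromatic group against another; the two compounds sitting at the limit of > 20000 nM in this assay, at which 2 of the 3 values shown sit, offer no number to build on. The expectation is therefore a step of no size beyond the scatter, a number no higher from compound 3 to compound 4 (the limit leaves the size open), and in this assay compound 4 is estimated at about 20000 nM, within 5000 nM to 60000 nM, probably again reported as a limit.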

Compound 4, half-maximal inhibitory concentration: > 20000 nM
Compound 4 ended at the assay's limit; the forecaster's own chance of this, stated with the estimate: 60%; the middle value lies on the limit itself.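

Compound 3 and compound 4 both end at a limit in this assay rather than at a real number, so no step can be read between them: the limit of > 20000 nM in this assay, at which 3 of the 4 values shown sit.

The compounds shown leave open whether the 3,4-dimethoxybenzyl and 4-methoxyphenyl groups differ at all in strength in this assay.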